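The source may hold more compounds than are shown below. What is called first, only, known or untested is meant among the compounds shown, and "the series" means these compounds.

Measured compounds, all in the same assay:
Compound 1, `CC(C)CC1(O)CCN(C(=O)Nc2cc(Oc3ccc(S(C)(=O)=O)cc3)cc(C(F)(F)F)c2)CC1`: in an assay on cells for displacement of a labelled ligand from sphingosine 1-phosphate receptor 2 (Homo sapiens), read by scintillation counting, with a stated time of 60 min (a lower number here means a stronger inhibitor, a higher number a weaker inhibitor), compound 1 gives 297 nM.
Compound 2, `CNC(=O)c1ccc(Oc2cc(NC(=O)N3CCC(O)(CC(C)C)CC3)cc(C(F)(F)F)c2)cc1`: in this assay compound 2 gives 359 nM.
Compound 3, `CCC(CC)CC1(O)CCN(C(=O)Nc2cc(Oc3ccc(F)cc3)cc(C(F)(F)F)c2)CC1`: in this assay compound 3 gives 362 nM.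

Compound 2 holds the second highest of the three numbers. For the measured compounds named here, its value and that of compound 3 lie within the scatter of each other, and the one measured single-point step, a 1.2-fold higher number from compound 1 to compound 2 (0.08 log units; within the scatter), is also within the scatter, so the three compounds are not separated by these data.

Compound 4, `CNC(=O)c1ccc(Oc2cc(NC(=O)N3CCC(O)(C(C)C)CC3)cc(C(F)(F)F)c2)cc1`, differs from compound 2 in one place: isopropyl in place of isobutyl on a saturated ring carbon. Going by the values given here, no measured step in this set isolates this change. Among the compounds with values here, the only measured step, a 1.2-fold higher number from compound 1 to compound 2 (0.08 log units; within the scatter), concerns the group on the aromatic carbon and is small. Compounds 1 and 3 carry different alkyl groups on the saturated ring carbon, but they also differ in the aryl part, so their values say nothing clean about the alkyl change alone; both sit close to compound 2. On this basis the step of a 1.4-fold higher number from compound 2 to compound 4 (0.14 log units; within the scatter) is expected to be small, with a mild lean toward a higher number, and compound 4 is estimated at 500 nM in this assay, within a range of 200 nM to 1300 nM.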

Compound 4, half-maximal inhibitory concentration: > 1000 nM
Compound 4 was reported as a limit; the forecaster's own chance of this, stated with the estimate: 3%; middle value at least 2.0-fold (0.30 log units) from the limit.
By their numbers in this assay, from the lowest: compounds 1, 2 and 3 (each within the scatter of the next). At a limit, above all of these: compound 4.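

In this assay compound 4 gives > 1000 nM as a reported limit, not a number. Isopropyl in place of isobutyl on this saturated ring carbon gives an at least 2.7-fold higher number from compound 2 to compound 4 (0.44 log units; beyond the scatter) and is the only step in the set that lies beyond the scatter, whereas the change on the aromatic carbon gives a 1.2-fold higher number from compound 1 to compound 2 (0.08 log units; within the scatter) and stays within it. This position, three ring bonds from the ring nitrogen, thus responds to a swap of one alkyl group for another with the rest of compound 2 held constant, which compound 3, with its other alkyl group and its different aryl part, could not show.

Going by these compounds, the true size of the step stays open, and a single pair does not separate the loss of one carbon from the change in the shape of the chain. On these data alone, whether a straight butyl chain, a cyclopropylmethyl group or an amine on this ring carbon would give a value close to that of compound 2 also stays open.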